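From compound 2 to compound 3: a hydroxy uncovered

The source may hold more compounds than are shown below. What is called first, only, known or untested is meant among the compounds shown, and "the series" means these compounds.

Measured in a toxicity assay (LMTK cells) for cytotoxicity, with Mus musculus as the target, read by MTT assay, with a stated time of 72 h; a higher number here means a weaker inhibitor, a lower number a stronger inhibitor:
- Compound 1 `Cc1c(C)c2c(c(C)c1OC(=O)CCC(=O)NC1CC(C)(C)N([O])C(C)(C)C1)CC[C@@](C)(CCC[C@H](C)CCC[C@H](C)CCCC(C)C)O2`: > 300000 nM
- Compound 2 `Cc1c(C)c2c(c(C)c1OC(=O)CCC(=O)O)CCC(C)(C(=O)NC1CC(C)(C)N([O])C(C)(C)C1)O2`: > 300000 nM

Compound 2 gives only a limit, > 300000 nM, and not a number. Compound 1 gives a limit too, so both sit at the limit of > 300000 nM in this assay, at which 2 of the 2 values shown sit, and no order can be read between them. Compound 3 `Cc1c(C)c2c(c(C)c1O)CCC(C)(C(=O)NC1CC(C)(C)N([O])C(C)(C)C1)O2` differs from compound 2 in one place: hydrogen in place of (2-carboxyethyl)carbonyl on an oxygen on an aromatic ring. The ((2-carboxyethyl)carbonyl)oxy becomes hydroxy. Among the measured compounds shown here, no measured step guides this change, so only a modest move towards stronger inhibition in this assay is expected, and compound 3 may well stay at the limit. The estimated change is an at least 1.5-fold lower number from compound 2 to compound 3 (0.17 log units; that floor lies within the scatter). For compound 3 the estimated value is 200000 nM, with an expected range of 70000 nM to 400000 nM.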

Compound 3, half-maximal inhibitory concentration: 252000 nM
Compound 3: the middle estimate sits 1.3-fold (0.10 log units) below what was measured, and the stated range covers the measured number.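

Before this result, the compounds gave no number in this assay: the limit of > 300000 nM in this assay, at which 2 of the 3 values shown sit. With hydrogen in place of (2-carboxyethyl)carbonyl on the oxygen on the aromatic ring, compound 3 gives a measured number rather than a limit, so a change at this position can bring the read-out off the limit. The result is an at least 1.1-fold lower number from compound 2 to compound 3 (0.07 log units; that floor lies within the scatter), and how large the true step is cannot be read. The compounds shown leave open how a methyl ether or an acetyl ester on this oxygen would read.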